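A few compounds are considered here, and "the series" means these few. Any claim that something is new, unique, unknown or untested is made for them only; others in the source may bear on it.

Compound 1 `C=Cc1c(C)nn(CC(C)CN2CCN(c3ccc(C)cc3)CC2)c(=O)c1N`: 17%
Compound 2 `Cc1c(C#N)c(-c2ccccc2)nn1CCCN1CCN(c2ccc(F)cc2)CC1`: 9%
Compound 3 `CC(=O)c1cccn1CCCN1CCN(c2ccc(F)cc2)CC1`: 0%

All three were tested in a functional assay on the whole organism (Abdomen, strain Swiss) for inhibition, with Mus musculus as the target, with stated times of 30 min, 10 min and 5 min, at a dose of 10 mg/kg by the oral route; on this read-out lower numbers stand for a weaker effect and higher numbers for a stronger effect at the one dose given. Compound 3 gives 0%, the smallest of the three numbers; compound 2, with 9%, sits within the scatter of it, whereas compound 1, with 17%, sits beyond the scatter above it. Compound 4 `COc1cccc(N2CCN(CCCn3cccc3C(C)=O)CC2)c1` has not been measured. It differs from compound 3 in one place: 3-methoxyphenyl in place of 4-fluorophenyl on an amine nitrogen in a ring. Going by the values given here, no step between two measured compounds shows what this change does on its own. A step from compound 3 to compound 4 that stays within the scatter is therefore expected, a number 5 percentage points higher from compound 3 to compound 4 (within the scatter), with its direction open. Compound 4 is estimated at 5%, in a range from 0% to 20%.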

Compound 4, a percentage reported as inhibition, in the whole organism at one dose (the size of the read-out at that dose, not a potency): 0%
Compound 4: middle estimate off by 5 percentage points, on the high side, within the range that was stated.
By their numbers in this assay, from the lowest: compounds 3, 4, 2 and 1 (each within the scatter of the next, the first and the last beyond it).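

Placing 3-methoxyphenyl in place of 4-fluorophenyl on the amine nitrogen in the ring gives no change at the digits printed from compound 3 to compound 4 (within the scatter) in this assay, the first direct reading of this change on this core. The hydrogen-bond acceptor counted in the 3-methoxyphenyl group thus brings no visible gain in this read-out at the one dose given. No measurement at hand accounts for this result.

As far as these compounds go, whether a 2-chlorophenyl or a pyridinyl group on that same nitrogen would raise the number on the core of compound 3 remains open. So does the outcome of a longer chain on this core.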